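The compounds below may be only part of what the source reports. "The series", "measured", "known", "first", "only" and "open" are said of these compounds alone.

Measured in an assay on CHO-K1 cells for displacement of a labelled ligand from prostaglandin E2 receptor EP1 subtype (Homo sapiens); a higher number here means a weaker inhibitor, a lower number a stronger inhibitor:
compound 1 `Cc1cc(C(=O)O)nn1Cc1cc(Br)ccc1OCc1ccc(Cl)cc1Cl` gives 0.132 nM.
compound 2 `Cc1cc(C(=O)O)nn1Cc1cc(Br)ccc1OCc1ccc(F)cc1F` gives 0.525 nM.
compound 3 `Cc1cc(C(=O)O)nn1Cc1cc(Cl)ccc1OCc1ccc(Cl)cc1Cl` gives < 2000 nM, which is a limit of the assay and not a number.

Compound 1 and compound 2 share a core and differ by 2,4-difluorophenyl in place of 2,4-dichlorophenyl on a saturated chain carbon bound to an oxygen on an aromatic ring; this change gave a 4.0-fold higher number from compound 1 to compound 2 (0.60 log units; beyond the scatter). Compound 3 carries a different core, differing from compound 1 by chloro in place of bromo on an aromatic carbon. The step that the limit leaves unreadable from compound 1 to compound 3 is unreadable; compound 3 sits at the limit of < 2000 nM in this assay, at which 1 of the 3 values shown sits.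

Compound 4 `Cc1cc(C(=O)O)nn1Cc1cc(Cl)ccc1OCc1ccc(F)cc1F`, not yet measured, differs from compound 3 by 2,4-difluorophenyl in place of 2,4-dichlorophenyl on a saturated chain carbon bound to an oxygen on an aromatic ring. The place of the change is the same word for word as in the change from compound 1 to compound 2, so this is the same change carried onto the core of compound 3. In this assay the expected step from compound 3 to compound 4 is a step that the limit leaves unreadable from compound 3 to compound 4, set beside a 4.0-fold higher number from compound 1 to compound 2 (0.60 log units; beyond the scatter); it rests on that single measured pair, and compound 3 offers no number to anchor it, so a limit rather than a number is again quite possible for compound 4. The estimate for compound 4 is 600 nM, expected to lie between 60 nM and 2000 nM.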

Compound 4, half-maximal inhibitory concentration: < 2000 nM
Compound 4 gave a limit, no number; the forecaster's own chance of this, stated with the estimate: 60%; the middle value does not contradict the limit.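

In this assay compound 4 gives < 2000 nM, a limit of the assay and not a number. The steps from compound 3 to compound 4 and from compound 2 to compound 4 cannot be read. The compounds shown leave open how much chloro in place of bromo costs, and whether the 2,4-difluorophenyl change keeps its size on the core of compound 3.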